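Swapping the remaining phenyl for a fluoropyridinyl group

The compounds below may be only part of what the source reports. "The series", "measured", "known", "first", "only" and "open" are said of these compounds alone.

Three compounds share a core with two amine nitrogens, each carrying an aromatic group, and were tested in a functional assay on MDA-MB-231 cells for antagonist activity at C-X-C chemokine receptor type 4 (Homo sapiens), tested at 100 nM; on this read-out higher numbers stand for a stronger effect at the one concentration tested and lower numbers for a weaker effect. Compound 1, `c1ccc(NCc2ccc(CNc3ccccc3)cc2)cc1`, gives 64%. Compound 2, `Fc1ccccc1NCc1ccc(CNc2ccccc2F)cc1`, which carries a fluorine on each phenyl, gives 58%. Compound 3, `c1ccc(NCc2ccc(CNc3ncccn3)cc2)cc1`, gives 100% and stands highest of the three; its nearest neighbour is compound 1, and compound 2 lies furthest below it.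

For the measured compounds named here, the step of a number 36 percentage points higher from compound 1 to compound 3 (beyond the scatter) is the one change in a single place that has been measured, and it shows that replacing a phenyl on an amine nitrogen with a six-membered aromatic ring containing nitrogen raised the read-out strongly.

Compound 4, `Fc1ccc(NCc2ccc(CNc3ncccn3)cc2)nc1`, takes the same idea to the other side of compound 3: 5-fluoropyridin-2-yl in place of phenyl on an amine nitrogen. Going by the values given here, no measured pair shows exactly this exchange, so the expectation rests on the direction seen from compound 1 to compound 3 alone. Because compound 3 already reaches 100%, there is little room for a further rise, and compound 4 is expected to stay close to it, with the step of a number 5 percentage points lower from compound 3 to compound 4 (within the scatter) anticipated to lie within the usual scatter. The estimate for compound 4 in this assay is 95%, with a plausible range from 80% to 100%.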

Compound 4, a percentage reported as inhibition, at one concentration (the size of the read-out at that concentration, not a potency): 78%
Beside the measured number, compound 4's estimate is 17 percentage points above it, and the stated range ends above it.
By their numbers in this assay, from the lowest: compounds 2 and 1 (each within the scatter of the next); then compound 4; then compound 3.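

In this assay, the remaining phenyl on an amine nitrogen turns out not to be a free place to exchange: with 5-fluoropyridin-2-yl there, the read-out falls, a number 22 percentage points lower from compound 3 to compound 4 (beyond the scatter). For the compounds shown here, until now, the only single-place change was the gain from phenyl to pyrimidin-2-yl, which could have suggested that a nitrogen-containing aromatic ring helps on either amine nitrogen, but this new step goes against that idea, so no such rule holds across these compounds. Nothing measured here explains the drop.

The change also brings in a ring nitrogen and a fluorine at once, so these compounds leave open which of the two goes with the lower number, or whether it takes both together. A plain pyridin-2-yl group on this amine nitrogen would help to separate the two, and a second pyrimidin-2-yl in the same place would show whether the gain seen with that ring carries over to the other side of the core.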